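Trifluoromethoxy in place of methyl on the phenoxy ring

A few compounds are considered here, and "the series" means these few. Any claim that something is new, unique, unknown or untested is made for them only; others in the source may bear on it.

The measured compounds:
Compound 1 `Cc1nn(C)c(Oc2ccc(OC(F)(F)F)cc2)c1/C=N\OCc1c(Cl)c(-c2ccc(F)cc2)nn1C` gives 2970 nM in a functional assay on SGC-7901 cells (Homo sapiens) for antiproliferative activity, read by MTT assay, with a stated time of 72 h; a lower number here means a stronger inhibitor, a higher number a weaker inhibitor.
Compound 2 `Cc1nn(C)c(Oc2ccc(Cl)cc2)c1/C=N\OCc1c(Cl)c(-c2ccc(Cl)cc2)nn1C` gives 7510 nM in this assay.
Compound 3 `Cc1ccc(Oc2c(/C=N\OCc3c(Cl)c(-c4ccc(Cl)cc4)nn3C)c(C)nn2C)cc1` gives 3730 nM in this assay.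

Compound 3 stands second highest of the three numbers. Its nearest neighbour is compound 1, and the two values lie within the usual scatter of each other; compound 2 is furthest from it, and the step of a 2.0-fold lower number from compound 2 to compound 3 (0.30 log units; within the scatter) is likewise within the scatter. No ordering among the three can therefore be claimed.

Compound 4 `Cc1nn(C)c(Oc2ccc(OC(F)(F)F)cc2)c1/C=N\OCc1c(Cl)c(-c2ccc(Cl)cc2)nn1C` has not yet been measured. It differs from compound 3 in one place: trifluoromethoxy in place of methyl on an aromatic carbon. Within the data shown here, the only measured step that touches this position is the step from compound 2 to compound 3, which replaced chloro with methyl and moved the number by a 2.0-fold lower number from compound 2 to compound 3 (0.30 log units; within the scatter). Among the measured compounds shown here, no measured step shows methyl replaced by trifluoromethoxy, so the direction must be read from compound 1, which carries the trifluoromethoxy group and gives 2970 nM, a value within the scatter of compound 3. Compound 4 is therefore expected to show a step of a 1.1-fold lower number from compound 3 to compound 4 (0.03 log units; within the scatter), not beyond the scatter. The estimate for compound 4 is 3500 nM, with a range from 1500 nM to 8000 nM.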

Compound 4, half-maximal inhibitory concentration: 3220 nM
Compound 4: middle estimate off by 1.1-fold (0.04 log units), on the high side; low and high end bracket the measured number.
By their numbers in this assay, from the lowest: compounds 1, 4, 3 and 2 (each within the scatter of the next, the first and the last beyond it).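

In this assay, trifluoromethoxy in place of methyl on the aromatic carbon para to a large group gives a 1.2-fold lower number from compound 3 to compound 4 (0.06 log units; within the scatter), so a group of 5 heavy atoms stands where a group of 1 stood without a difference that can be read. The same position yields the first step there to pass the scatter, though only modestly: trifluoromethoxy in place of chloro gives a 2.3-fold lower number from compound 2 to compound 4 (0.37 log units; beyond the scatter), whereas methyl in place of chloro gave a 2.0-fold lower number from compound 2 to compound 3 (0.30 log units; within the scatter) and stayed within it. Among these compounds, at the other site that varies, chloro in place of fluoro on an aromatic carbon gives a 1.1-fold higher number from compound 1 to compound 4 (0.04 log units; within the scatter), the first direct look at that change, and no difference can be read from it.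

Nothing at hand accounts for these numbers. On these data alone, it remains open whether an amine, a carboxylic acid or a longer alkoxy chain at this position would move the number further than chloro, methyl and trifluoromethoxy do, and whether the modest step from chloro to trifluoromethoxy would recur with fluoro at the other site.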